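The source may hold more compounds than are shown below. What is called first, only, known or untested is meant among the compounds shown, and "the series" means these compounds.

Measured so far in a physicochemical assay for solubility, measured as kinetic solubility; on this read-out higher numbers stand for higher solubility and lower numbers for lower solubility:
- compound 1, `Cc1cc(C)c(CN2CCc3c(Cl)cc([C@@H](CO)[C@@H]4CCOC4)c(Cl)c3C2=O)c(=O)[nH]1`: 537000 nM
- compound 2, `COC(c1cc(Cl)c2c(c1Cl)C(=O)N(Cc1c(C)cc(C)[nH]c1=O)CC2)C1CCN(C2COC2)CC1`: 523000 nM; 519000 nM (2 entries)
- compound 3, `COC(c1cc(Cl)c2c(c1Cl)C(=O)N(Cc1c(C)cc(C)[nH]c1=O)CC2)C1CCN(C(C)=O)CC1`: 532000 nM; 498000 nM (2 entries)

Going by the values given here, compound 1 gives the only single-entry number among the three; compounds 2 and 3 each have several entries, the several entries of compound 2 in this assay, 523000 nM; 519000 nM (2 entries) and (the several entries of compound 3 in this assay, 532000 nM; 498000 nM (2 entries)), and all three values lie within the scatter of one another. No step between measured compounds is shown, so no measured step guides the change from compound 1 to compound 4, `Cc1cc(C)c(CN2CCc3c(Cl)cc([C@@H](C)CO)c(Cl)c3C2=O)c(=O)[nH]1`, which is a group of 4 heavy atoms (3 carbon, 1 oxygen; no ring) in place of a group of 8 heavy atoms (6 carbon, 2 oxygen; one five-membered non-aromatic ring with 1 hetero atom), on an aromatic carbon. Since compounds 1, 2 and 3 all sit at the same level in this assay despite their different substituents, the step of a 1.0-fold lower number from compound 1 to compound 4 (0.01 log units; within the scatter) is expected to be none beyond the scatter. Compound 4 is therefore expected to give about 520000 nM, within 380000 nM to 580000 nM.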

Compound 4, solubility: 143000 nM
Compound 4: the middle estimate sits 3.6-fold (0.56 log units) above what was measured, and the stated range ends above it.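

In this assay, the aromatic carbon ortho to a chloro group proves sensitive to what it carries: 1-(hydroxymethyl)ethyl in place of the larger ring-bearing group gives a 3.8-fold lower number from compound 1 to compound 4 (0.57 log units; beyond the scatter). This is the only step shown at this position, and it is wider than the agreement between repeat entries: the several entries of compound 2 in this assay, 523000 nM; 519000 nM (2 entries)

This one step cannot separate the loss of the five-membered ring from the loss of the rest of the group. As far as these compounds go, whether a longer chain or an amine at this position would restore the higher number remains open.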